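Swapping formyl for chloro on a shared imidazopyrazine scaffold

The source may hold more compounds than are shown below. What is called first, only, known or untested is meant among the compounds shown, and "the series" means these compounds.

Measured compounds:
compound 1, `COc1ccc(-c2cn3ccnc3c(-c3ccc4ncn(C5CCCCC5)c4c3)n2)cc1`: 65.2%
compound 2, `O=Cc1ccc(-c2cn3ccnc3c(-c3ccc4ncn(C5CCCCC5)c4c3)n2)cc1`: 37.1%
compound 3, `CC(=O)c1ccc(-c2cn3ccnc3c(-c3ccc4ncn(C5CCCCC5)c4c3)n2)cc1`: 18.5%

Three compounds share one core and differ only in the group on the outer benzene ring. In a functional assay on UACC-62 cells (Homo sapiens) for inhibition, read by sulforhodamine B assay, with a stated time of 48 h, tested at 10 uM (a lower number here means less inhibition, a higher number more inhibition at the concentration tested (going by the name of the read-out)), compound 1 gives 65.2%, compound 2 gives 37.1% and compound 3 gives 18.5%. Compound 2 stands second highest of the three: the step of a number 28.1 percentage points lower from compound 1 to compound 2 (beyond the scatter) is modest, and the step of a number 18.6 percentage points lower from compound 2 to compound 3 (beyond the scatter) is modest as well, while the step of a number 46.7 percentage points lower from compound 1 to compound 3 (beyond the scatter) is large.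

Compound 4, `Clc1ccc(-c2cn3ccnc3c(-c3ccc4ncn(C5CCCCC5)c4c3)n2)cc1`, is not yet measured. The change from compound 2 is chloro in place of formyl on an aromatic carbon. Among the measured compounds shown here, no measured step involves chloro, so only the general lesson applies: the two steps around compound 2 show that this position alone moves the read-out in this assay by modest to large amounts, in either direction. A step of either sign beyond the scatter is therefore possible, and the expected step is a number 10.9 percentage points higher from compound 2 to compound 4 (beyond the scatter). For compound 4 the estimated value in this assay is 48%, with a range from 20% to 78%.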

Compound 4, a percentage reported as inhibition, at one concentration (the size of the read-out at that concentration, not a potency): 30.5%
Compound 4: middle estimate off by 17.5 percentage points, on the high side; the range from low to high includes it.
By their numbers in this assay, from the lowest: compound 3; then compounds 4 and 2 (each within the scatter of the next); then compound 1.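

In this assay, replacing formyl with chloro gives a number 6.6 percentage points lower from compound 2 to compound 4 (within the scatter), so two groups that share neither atoms nor a carbonyl cannot be told apart at this place on the ring. Chloro still separates from the other two groups, with a number 12 percentage points higher from compound 3 to compound 4 (beyond the scatter) and a number 34.7 percentage points lower from compound 1 to compound 4 (beyond the scatter), which leaves compound 1 with the highest number of the four and compound 3 with the lowest. Nothing available explains why these groups read as they do.

Going by these compounds, whether the high number of compound 1 belongs to methoxy alone, or would also appear with ethoxy, a hydroxyl or an amine, stays open. It is also open whether fluoro or bromo would read like chloro, and a reading at one concentration gives no potency for any of these compounds.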